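The source may hold more compounds than are shown below. What is called first, only, known or untested is meant among the compounds shown, and "the series" means these compounds.

Measured so far:
compound 1 `COc1cc(/C=C/C(=O)c2cccc(-n3cc(-c4ccc(Cl)cc4)[nH]c3=O)c2)cc(OC)c1OC` gives 5140 nM in a functional assay on SN12C cells (Homo sapiens) for inhibition; a higher number here means a weaker inhibitor of growth, a lower number a stronger inhibitor of growth
compound 2 `O=C(/C=C/c1cccc(O)c1)c1cccc(-n2cc(-c3ccccc3)[nH]c2=O)c1` gives 3140 nM in this assay
compound 3 `COc1ccc(-c2cn(-c3cccc(C(=O)/C=C/c4ccc(O)c(OC)c4)c3)c(=O)[nH]2)cc1` gives 4110 nM in this assay

The three compounds share a core and differ in the groups at either end. In this assay compound 1 gives the highest of the three numbers, yet its gaps to compound 3 and to compound 2 both fall within the usual scatter, so no order among the three can be read from these values.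

Compound 4 `COc1cc(/C=C/C(=O)c2cccc(-n3cc(-c4cc(OC)c(OC)c(OC)c4)[nH]c3=O)c2)cc(OC)c1OC` has not yet been measured. Compared with compound 1 it carries 3,4,5-trimethoxyphenyl in place of 4-chlorophenyl on an aromatic carbon. For the measured compounds named here, no pair of measured compounds differs in this one place alone, so the size of this step cannot be read from the data; the three measured values sit close together, and no step beyond the scatter is expected in either direction. From compound 1 to compound 4 the estimated step is a 1.4-fold lower number from compound 1 to compound 4 (0.13 log units; within the scatter). Compound 4 is therefore expected to give about 3800 nM in this assay, with a range from 1300 nM to 11000 nM.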

Compound 4, concentration for 50% growth inhibition: 2750 nM
Estimate against measurement, compound 4: 1.4-fold (0.14 log units) above; measured number inside the range.
By their numbers in this assay, from the lowest: compounds 4, 2, 3 and 1 (each within the scatter of the next).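

In this assay, for the compounds shown here, the first change in one place that can be read is 3,4,5-trimethoxyphenyl in place of 4-chlorophenyl on the aromatic carbon of the five-membered ring, with a 1.9-fold lower number from compound 1 to compound 4 (0.27 log units; within the scatter). This position therefore accepts a group of 12 heavy atoms with 3 hydrogen-bond acceptors in place of one of 7 heavy atoms with none, and the step stays within the scatter. Nothing available bears on why this step is so small.

The compounds shown leave open whether an amine or a carboxylic acid in place of the 3,4,5-trimethoxyphenyl would give a step beyond the scatter. No pair shown differs only at the other end of the shared core, so the size of any step there cannot be read.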